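Swapping a Pyridine for a Pyrazine on the Amide

The source may report more compounds than this note shows. Statements on the series, on what has been measured and on what is new or still open speak of the compounds shown alone.

Measured so far in an assay on HEK293 cells for agonist activity at Toll-like receptor 8 (Homo sapiens), read by a luciferase reporter, with a stated time of 6 h; a higher number here means that more compound is needed for the effect, a lower number that less compound is needed:
Compound 1, `CCCCNc1nc(N)nc2c1CNCC2`, gives 7.2 uM.
Compound 2, `CCCCNc1nc(N)nc2c1CN(C(=O)c1ccccc1)CC2`, gives 1.4 uM.
Compound 3, `CCCCNc1nc(N)nc2c1CN(C(=O)c1ccncc1)CC2`, gives > 25 uM, which is a limit of the assay rather than a number.

Compound 3 therefore stands at the weak end of the three: in this assay it reads only as a limit, (the limit of > 25 uM in this assay, at which 1 of the 3 values shown sits), whereas compound 1 and compound 2 each give a number. Compound 4, `CCCCNc1nc(N)nc2c1CN(C(=O)c1cnccn1)CC2`, differs from compound 3 in one place: pyrazin-2-yl in place of pyridin-4-yl on a carbonyl carbon. Within the data shown here, two measured steps bear on this. Putting benzoyl onto the ring nitrogen gave a 5.1-fold lower number from compound 1 to compound 2 (0.71 log units; beyond the scatter), while the same carbonyl carrying pyridin-4-yl gave an at least 3.4-fold higher number from compound 1 to compound 3 (0.54 log units; beyond the scatter), so that an at least 17-fold higher number from compound 2 to compound 3 (1.25 log units; beyond the scatter). The new change thus lands on a compound already at the limit, and the direction of any further movement is uncertain. Compound 4 is expected to remain weak, with a number no higher from compound 3 to compound 4 (the limit leaves the size open), and the estimate for compound 4 is 25 uM, between 8 uM and 80 uM.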

Compound 4, minimum effective concentration: 2.2 uM
Beside the measured number, compound 4's estimate is 11-fold (1.06 log units) above it; measured number outside the range, below it.
By their numbers in this assay, from the lowest: compounds 2 and 4 (each within the scatter of the next); then compound 1. At a limit, above all of these: compound 3.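

In this assay, the choice of aromatic ring on this carbonyl carbon matters greatly, as pyrazin-2-yl in place of pyridin-4-yl gives an at least 11-fold lower number from compound 3 to compound 4 (1.05 log units; beyond the scatter). Going by these compounds, compound 3 reads only as a limit and not as a number, so the true size of that step stays unknown: the limit of > 25 uM in this assay, at which 1 of the 4 values shown sits. A hetero atom in this ring therefore does not by itself cost activity, since pyrazin-2-yl in place of phenyl gives a 1.6-fold higher number from compound 2 to compound 4 (0.20 log units; within the scatter), and adding the whole (pyrazin-2-yl)carbonyl group to the amine nitrogen in the ring gives a 3.3-fold lower number from compound 1 to compound 4 (0.51 log units; beyond the scatter).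

Pyridin-4-yl and pyrazin-2-yl differ both in how many ring nitrogens they carry and in where those nitrogens sit, and the compounds shown cannot separate these two differences. Pyridin-2-yl or pyrimidin-4-yl on the same carbonyl carbon would help to pull them apart.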